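The source may hold more compounds than are shown below. What is called first, only, known or untested is meant among the compounds shown, and "the series" means these compounds.

Of the compounds shown here, three that share one core have been read in a functional assay on SW480 cells (Homo sapiens) for antiproliferative activity, read by MTT assay, with a stated time of 48 h; on this read-out higher numbers stand for weaker inhibition and lower numbers for stronger inhibition. In this assay compound 1 `CC(C)=CCC[C@]1(C)/C=C/[C@@H](OC(=O)C=C(C)C)[C@](C)(O)/C=C/C(=O)/C(CN(C)C)=C\C1` gives 480 nM, compound 2 `CC(C)=CCC[C@]1(C)/C=C/[C@@H](OC(=O)C=C(C)C)[C@](C)(O)/C=C/C(=O)/C(CN(C(C)C)C(C)C)=C\C1` gives 750 nM, and compound 3 `CC(C)=CCC[C@]1(C)/C=C/[C@@H](OC(=O)C=C(C)C)[C@](C)(O)/C=C/C(=O)/C(COC(=O)c2ccc([N+](=O)[O-])cc2)=C\C1` gives 570 nM. Compound 3 cannot be separated from either of the others, as the record shows a 1.2-fold higher number from compound 1 to compound 3 (0.07 log units; within the scatter) and a 1.3-fold lower number from compound 2 to compound 3 (0.12 log units; within the scatter).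

The next compound, compound 4 `CC(C)=CCC[C@]1(C)/C=C/[C@@H](OC(=O)C=C(C)C)[C@](C)(O)/C=C/C(=O)/C(CN=[N+]=[N-])=C\C1`, has azido in place of ((4-nitrophenyl)carbonyl)oxy on a saturated chain carbon bound to a double-bonded ring carbon. For the measured compounds named here, no measured compound carries azido, so no step speaks to this group directly. The nearest evidence comes from the three exchanges already made at this same place. Besides the two steps to compound 3, the swap of dimethylamino for diisopropylamino gives a 1.6-fold higher number from compound 1 to compound 2 (0.19 log units; within the scatter). All three steps stay within the scatter, even though the groups involved differ widely. On that evidence alone, no step beyond the scatter is expected in this assay, and no direction can be favoured. The expected step is a 1.0-fold lower number from compound 3 to compound 4 (0.01 log units; within the scatter). Compound 4 is estimated at 560 nM. For compound 4 the expected range runs from 250 nM to 1250 nM.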

Compound 4, half-maximal inhibitory concentration: 4230 nM
Compound 4: middle estimate off by 7.6-fold (0.88 log units), on the low side; the measured number lies above the stated range.
By their numbers in this assay, from the lowest: compounds 1, 3 and 2 (each within the scatter of the next); then compound 4.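

The position is not indifferent to what it carries in this assay. Azido is the first group on the saturated chain carbon bound to a double-bonded ring carbon to move the number beyond the scatter, with a 7.4-fold higher number from compound 3 to compound 4 (0.87 log units; beyond the scatter), a 5.6-fold higher number from compound 2 to compound 4 (0.75 log units; beyond the scatter) and an 8.8-fold higher number from compound 1 to compound 4 (0.95 log units; beyond the scatter), which makes compound 4 the weakest of the four, while dimethylamino, diisopropylamino and ((4-nitrophenyl)carbonyl)oxy remain within the scatter of one another. The wide latitude suggested by the earlier exchanges therefore does not extend to every group at this place, although nothing available here bears on what sets azido apart.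

The compounds shown leave open whether the weaker number belongs to azido alone or is shared by other small groups, such as a primary amine, a hydroxyl or a carboxylic acid, at this same place. They also leave open whether a cyclic amine such as morpholine or a longer ester chain would read like compound 1 and compound 3 or like compound 4.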